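The source may report more compounds than this note shows. Statements on the series, on what has been measured and on what is new or still open speak of the compounds shown alone.

Measured so far:
compound 1 `C[C@@H](Cn1ccc(-c2ccc(C#N)c(Cl)c2)n1)Nc1cccc2ccccc12` — 870 nM
compound 2 `C[C@@H](Cn1ccc(-c2ccc(C#N)c(Cl)c2)n1)Nc1ncnc2ccccc12` — 510 nM

In a functional assay on LNCaP cells (Homo sapiens) for antiproliferative activity, read by CCK-8 assay, with a stated time of 6 days (a lower number here means a stronger inhibitor, a higher number a weaker inhibitor), compound 1 gives 870 nM and compound 2 gives 510 nM; the two numbers lie within the usual scatter of each other, so no order between them is claimed. Compound 3 `C[C@H](Cn1ccc(-c2ccc(C#N)c(Cl)c2)n1)Nc1ncnc2ccccc12` remains to be measured in this assay. Compound 3 differs from compound 2 as follows: the two compounds have the same atoms and bonds and differ only in configuration as drawn: 1 of 1 stereo elements differ; a stereocentre at a saturated chain carbon is drawn S in compound 2 and R in compound 3. Among the measured compounds shown here, no pair of measured compounds shows a change of this kind, so the size and direction of the step rest on nothing measured here. The step expected, a 5.9-fold higher number from compound 2 to compound 3 (0.77 log units; beyond the scatter), is toward a higher number, likely beyond the scatter, held with low confidence. Compound 3 is estimated at 3000 nM, with a range from 700 nM to 15000 nM.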

Compound 3, half-maximal inhibitory concentration: 970 nM
Compound 3: the middle estimate sits 3.1-fold (0.49 log units) above what was measured; measured number inside the range.
By their numbers in this assay, from the lowest: compounds 2, 1 and 3 (each within the scatter of the next).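

Inverting the stereocentre at the saturated chain carbon gives a 1.9-fold higher number from compound 2 to compound 3 (0.28 log units; within the scatter) in this assay and is the first measured change at this position. Neither the S nor the R drawing is shown to be favoured here, as this step lies within the scatter. The comparison carries no other structural change: the fact that compounds 2 and 3 differ only in the configuration as drawn.

From the compounds shown here alone, it remains open whether inversion would also stay within the scatter on the core of compound 1. Also open, going by these compounds, is whether a longer chain or a carboxylic acid at this stereocentre would separate the two configurations.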